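The source may hold more compounds than are shown below. What is called first, only, known or untested is meant among the compounds shown, and "the series" means these compounds.

Within the data shown here, compound 2 `Nc1nc(-c2ccc(Cl)o2)nc2sc(CN3CC=CCC3)cc12` stands lowest of the two numbers so far in an assay on CHO-K1 cells for antagonist activity at adenosine receptor A1 (Homo sapiens), read by a beta-galactosidase reporter, with stated times of 15 min and 6 h; on this read-out higher numbers stand for weaker inhibition and lower numbers for stronger inhibition: compound 2 gives 190 nM, while compound 1 `Nc1nc(-c2ccc(Cl)o2)nc2sc(CN3CCCC3)cc12` gives 710 nM. Among the measured compounds shown here, the one step measured between them, a 3.7-fold lower number from compound 1 to compound 2 (0.57 log units; beyond the scatter), changes only the ring on the saturated chain carbon bound to an aromatic carbon; the group on the shared core is the same in both.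

Compound 3 `Nc1nc(-c2ncco2)nc2sc(CN3CC=CCC3)cc12` carries a different change: 1,3-oxazol-2-yl in place of 5-chlorofuran-2-yl on an aromatic carbon, with the ring on the saturated chain carbon kept as in compound 2. For the measured compounds named here, none of the measured steps touches this position, so the size and direction of the step in this assay cannot be read from them; the only anchor is the value of compound 2. On that basis the expectation for compound 3 is a step of a 2.6-fold higher number from compound 2 to compound 3 (0.42 log units; beyond the scatter), with wide uncertainty in either direction. Compound 3 is therefore estimated at 500 nM, with a range from 120 nM to 2500 nM.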

Compound 3, inhibition constant: 2960 nM
The estimate for compound 3 lay 5.9-fold (0.77 log units) below the measured number; measured number above the stated range.
By their numbers in this assay, from the lowest: compound 2; then compound 1; then compound 3.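

In this assay, the aromatic carbon between two ring nitrogen atoms proves to be a place where the number responds strongly: 1,3-oxazol-2-yl in place of 5-chlorofuran-2-yl gives a 16-fold higher number from compound 2 to compound 3 (1.19 log units; beyond the scatter) on this shared core. This large step runs against the ring change on the saturated chain carbon, which gave a 3.7-fold lower number from compound 1 to compound 2 (0.57 log units; beyond the scatter) and lowered the number, so the group at this aromatic carbon can outweigh that earlier gain. The swap removes the chlorine and adds a second hetero atom to the ring at once, and nothing measured here bears on why the number rises.

The pair leaves open how much of the step belongs to the chlorine and how much to the ring itself, a question that plain furan-2-yl, 5-methylfuran-2-yl or 5-chlorothiophen-2-yl at the same carbon would help to separate. It also leaves open whether the step keeps its size with the five-membered ring of compound 1 on the saturated chain carbon, or with an open-chain diethylamine there.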